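Notes on the triazole aryl change in the spiro series

This account rests on a few compounds, and the source may have more. Where it says the series, first, only, none or still open, it means among the compounds named here.

Measured compounds:
compound 1 `N#CC1=C(N)Oc2c(c3nc4ccccc4nc3c3ccccc23)C12C(=O)N(Cc1cnnn1-c1cccc(S(N)(=O)=O)c1)c1ccccc12` — a functional assay on HCT-116 cells (Homo sapiens) for antiproliferative activity, read by MTT assay, with a stated time of 48 h; a higher number here means a weaker inhibitor, a lower number a stronger inhibitor: 11300 nM
compound 2 `N#CC1=C(N)Oc2c(c3nc4ccccc4nc3c3ccccc23)C12C(=O)N(Cc1cnnn1-c1ccc(Cl)c(Cl)c1)c1ccccc12` — > 50000 nM, a limit of the assay and not a number
compound 3 `N#CC1=C(N)Oc2c(N)cc3nc4ccccc4nc3c2C12C(=O)N(Cc1cnnn1-c1ccc(F)cc1)c1ccccc12` — > 50000 nM, a limit of the assay and not a number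

Compound 3 stands at the top of the numbers shown in this assay; its value is a limit, and the limit of > 50000 nM in this assay, at which 2 of the 3 values shown sit, tells that two of the three values shown sit there. Compound 4 `CCc1cccc(CC)c1-n1nncc1CN1C(=O)C2(C(C#N)=C(N)Oc3c(N)cc4nc5ccccc5nc4c32)c2ccccc21` has not been measured. It differs from compound 3 in one place: 2,6-diethylphenyl in place of 4-fluorophenyl on an aromatic nitrogen. Among the measured compounds shown here, the single measured step, an at least 4.4-fold higher number from compound 1 to compound 2 (0.64 log units; beyond the scatter), also exchanges the aryl on the same aromatic nitrogen, though on a core without the amino group of compound 3, and it moved the number from a measured value up to the limit. For the measured compounds named here, no measured step shows an aryl change from a compound that already sits at the limit, so the expectation rests on that step alone: no gain, and a number at or past the limit. Compound 4 is expected to give 60000 nM, in the range 20000 nM to 200000 nM. The expected step is a step that the limit leaves unreadable from compound 3 to compound 4, most likely reported again as a limit.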

Compound 4, half-maximal inhibitory concentration: 37600 nM
The estimate for compound 4 lay 1.6-fold (0.20 log units) above the measured number; measured number inside the range.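

On the core carrying the amino group, the aryl on this aromatic nitrogen can be exchanged with a measured number as the result: in this assay compound 4 gives 37600 nM. The exchange is read as an at least 1.3-fold lower number from compound 3 to compound 4 (0.12 log units; that floor lies within the scatter), so no gain in potency can be claimed, although 2,6-diethylphenyl is tolerated at least as well as 4-fluorophenyl in this assay, with both groups counting no hydrogen-bond donors or acceptors. The true size of the step stays unknown because the value of compound 3 is a limit of the assay: the limit of > 50000 nM in this assay, at which 2 of the 4 values shown sit.

Going by these compounds, whether a carboxylic acid or a dimethylamino group on this aryl ring would lower the number further remains open. Also open, on these data alone, is what longer chains, such as propyl in place of ethyl, would do at this position.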